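This account rests on a few compounds, and the source may have more. Where it says the series, first, only, none or still open, it means among the compounds named here.

Two measured compounds frame this account. Compound 1, `CCCCCCCCCCCOc1ccccc1CCC(=O)OCc1ccccc1OP(=O)(O)OC[C@H](N)C(=O)O`, was tested in an assay on HEK293-A cells with probable G-protein coupled receptor 34 (Mus musculus) as the target, with a stated time of 1.5 h (a lower number here means a smaller maximal response, a higher number a larger maximal response), where compound 1 reaches 0.2. Compound 2, `Cc1ccc(Oc2cccc(COc3ccccc3CCC(=O)O[C@@H]3CCCO[C@@H]3COP(=O)(O)OC[C@H](N)C(=O)O)c2)cc1`, gives in this assay a value of 1.9, the higher of the two numbers, standing beyond the scatter above compound 1. Going by the values given here, no single-change step between the two measured compounds is available, so the two values can only be set side by side.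

The unmeasured compound 3, `N[C@@H](COP(=O)(O)OC[C@H]1OCCC[C@H]1OC(=O)CCc1ccccc1OCc1cccc(Oc2ccc(Cl)cc2)c1)C(=O)O`, differs from compound 2 in one place: chloro in place of methyl on an aromatic carbon. The exchange of methyl for chloro on an aromatic carbon, para to a large group, keeps the count of heavy atoms, the absence of ring, donors and acceptors, and the absence of charge unchanged.

Among the compounds with values here, with no measured step of this kind to draw on, no shift beyond the scatter is expected from compound 2 to compound 3 in this assay; the expected step is a number 0.10 lower from compound 2 to compound 3 (within the scatter). Compound 3 is therefore estimated to reach 1.8 in this assay, with an expected range from 1.3 to 2.4.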

Compound 3, intrinsic activity: the largest response reached, as a fraction of the reference agonist's: 1.2
Compound 3: middle estimate off by 0.60, on the high side; the measured number lies below the stated range.
By their numbers in this assay, from the lowest: compound 1; then compound 3; then compound 2.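

Going by these compounds alone, the exchange of 4-methylphenyl for 4-chlorophenyl, on an aromatic carbon para to a large group, gives a number 0.70 lower from compound 2 to compound 3 (beyond the scatter) in this assay and so provides the first reading of a single change in this set. Compounds 1 and 2 differ in more than one place and could only be set side by side, whereas this step shows that the largest response reached is sensitive to what stands at this one position, even though the two groups match in the counts of heavy atoms, rings, hydrogen-bond donors and acceptors, and net charge. Nothing shown here accounts for the size or the direction of this step.

From the compounds shown here alone, what remains open is how other groups would behave on this same aromatic carbon, such as a hydrogen, a fluoro, a methoxy, a trifluoromethyl or an amine, and whether the response follows any order across such a series. Within the data shown here, with only one step at this position, it also remains open whether the exchange of methyl for chloro would give a similar step on a different core.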